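The source may hold more compounds than are shown below. What is called first, only, known or untested is meant among the compounds shown, and "the series" means these compounds.

Compound 1 `CC(C)(C)Sc1c(O)nc2ccc(C(F)(F)F)cc2c1-c1cc(Cl)ccc1O`: < 1 ug/mL (a limit)
Compound 2 `OCC(O)CSc1c(O)nc2ccc(C(F)(F)F)cc2c1-c1cc(Cl)ccc1O`: 190 ug/mL

Among the measured compounds shown here, in a physicochemical assay for solubility (on this read-out higher numbers stand for higher solubility and lower numbers for lower solubility), compound 2 gives 190 ug/mL, the only actual number so far. The entry for compound 1 is < 1 ug/mL, which is a limit of the assay and not a number.

Next comes compound 3 `CCNC(CO)Sc1c(O)nc2ccc(C(F)(F)F)cc2c1-c1cc(Cl)ccc1O`, which carries 1-(ethylamino)-2-hydroxyethyl in place of 2,3-dihydroxypropyl on a sulfur.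

For the measured compounds named here, one measured step bears on this sulfur: an at least 190-fold higher number from compound 1 to compound 2 (2.27 log units; beyond the scatter). That step replaced tert-butyl, so it gives only indirect guidance, as neither group of the new change was involved except the one now leaving. The expected outcome in this assay is a 1.3-fold lower number from compound 2 to compound 3 (0.10 log units; within the scatter), which means no expected step beyond the scatter and no expected direction. For compound 3 the estimated value is 150 ug/mL, with an expected range of 40 ug/mL to 600 ug/mL.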

Compound 3, solubility: > 1900 ug/mL
Compound 3: only a limit was reported; the forecaster's own chance of this, stated with the estimate: 3%; middle value at least 12-fold (1.10 log units) away from the limit.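

At this sulfur, 1-(ethylamino)-2-hydroxyethyl in place of 2,3-dihydroxypropyl leaves the hydrogen-bond donor and acceptor counts as they were, with no net charge on either group, and this assay still shows an at least 10-fold higher number from compound 2 to compound 3 (1.00 log units; beyond the scatter). Against tert-butyl, the same group gives an at least 1900-fold higher number from compound 1 to compound 3 (3.27 log units; beyond the scatter), so the range open at this position is wider than the earlier step showed. Compound 3 stands at a limit and not at a number: the limit of > 1900 ug/mL in this assay, at which 1 of the 3 values shown sits.

The compounds shown leave open whether the step follows the ethylamino part or the rest of the new chain; a plain amine such as 2-aminoethyl, or a carboxylic acid, on the same sulfur would separate these readings. As far as these compounds go, how far the solubility of compound 3 lies past its limit also stays unknown.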